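Swapping the Hexyl Tail for Benzyl on the Urea

This account rests on a few compounds, and the source may have more. Where it says the series, first, only, none or still open, it means among the compounds named here.

Of the compounds shown here, two with a shared core have been measured in a functional assay on membranes from Sf9 cells for agonist activity at histamine H2 receptor (Homo sapiens), read by scintillation counting and GTPgammaS binding, with a stated time of 90 min; on this read-out lower numbers stand for an effect already at smaller amounts and higher numbers for an effect only at larger amounts of compound. Compound 1 `CCCNC(=O)/N=C(\N)NCCCc1sc(N)nc1C` gives 178 nM. Compound 2 `CCCCCCNC(=O)/N=C(\N)NCCCc1sc(N)nc1C` gives 38.9 nM, the lower of the two numbers. Among the compounds with values here, the only measured step, a 4.6-fold lower number from compound 1 to compound 2 (0.66 log units; beyond the scatter), came from propyl in place of hydrogen on a saturated chain carbon, three bonds along the chain from an amide-type nitrogen. Compound 3 `Cc1nc(N)sc1CCCN/C(N)=N/C(=O)NCc1ccccc1` has not been measured. It differs from compound 2 by phenyl in place of pentyl on a saturated chain carbon bound to an amide-type nitrogen. The measured step bears on this only loosely: it shows that a longer chain on this side lowered the number, whereas the new change trades most of that chain for a ring of similar size rather than removing it. The step from compound 2 to compound 3 in this assay is therefore expected to be a 1.7-fold higher number from compound 2 to compound 3 (0.22 log units; within the scatter), most likely within the scatter or a small rise. Compound 3 is estimated at 65 nM, with a range from 20 nM to 220 nM.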

Compound 3, half-maximal effective concentration: 28.8 nM
Beside the measured number, compound 3's estimate is 2.3-fold (0.35 log units) above it, and the stated range covers the measured number.
By their numbers in this assay, from the lowest: compounds 3 and 2 (each within the scatter of the next); then compound 1.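

In this assay, within the data shown here, the earlier compounds showed only that the longer of two open chains gave the lower number, yet benzyl in place of hexyl gives a 1.4-fold lower number from compound 2 to compound 3 (0.13 log units; within the scatter), so a six-membered aromatic ring serves at this position about as well as the hexyl chain. Measured against the propyl group of compound 1, the benzyl group gives a 6.2-fold lower number from compound 1 to compound 3 (0.79 log units; beyond the scatter), which means that a long open alkyl chain is not required here for a number in this range. Nothing available explains why the ring and the chain read alike.

Still open, as far as these compounds go, is how a phenethyl group, with its longer chain carrying the phenyl, would read at this position. The same holds for a pyridyl ring, a fluorophenyl ring or a hexyl chain ending in an amine.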